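This account rests on a few compounds, and the source may have more. Where it says the series, first, only, none or still open, it means among the compounds named here.

Compound 1 `Fc1cccc(/C=C/c2ccccc2)c1` gives 3100 nM; compound 2 `COc1cccc(/C=C/c2ccc(F)cc2)c1` gives 6000 nM; compound 3 `COc1cccc(/C=C/c2cccc(F)c2)c1` gives 2300 nM.

All three were tested in an assay on HepG2 cells for activation of nuclear factor erythroid 2-related factor 2 (Homo sapiens), read by a luciferase reporter, with a stated time of 5 h; on this read-out higher numbers stand for an effect only at larger amounts of compound and lower numbers for an effect already at smaller amounts. Compound 1 and compound 2 have different cores, and the difference between the two cores is not broken down here. Compound 3 arises from compound 1 by a single change, (methoxy in place of hydrogen on an aromatic carbon), and that change made a 1.3-fold lower number from compound 1 to compound 3 (0.13 log units; within the scatter), so the two numbers cannot be told apart. Compound 2 has the highest of the three numbers, but its gap to compound 1 lies within the scatter, while its gap to compound 3 lies beyond it.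

Compound 4 `COc1cccc(/C=C/c2ccc(F)cc2)c1OC` is not yet measured. It arises from compound 2 by methoxy in place of hydrogen on an aromatic carbon. Among the measured compounds shown here, this is the same kind of change as the one from compound 1 to compound 3, though not the same: there the new group sat meta to a group of 9 heavy atoms, here it sits ortho to a group of 9 heavy atoms and ortho to a methoxy group. For the measured compounds named here, because the earlier step was a 1.3-fold lower number from compound 1 to compound 3 (0.13 log units; within the scatter), a small step is expected here as well, a 1.2-fold lower number from compound 2 to compound 4 (0.08 log units; within the scatter), on the one example only. Compound 4 is therefore estimated at 5000 nM, in a range from 1800 nM to 14000 nM.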

Compound 4, half-maximal effective concentration: 2900 nM
Compound 4: the middle estimate sits 1.7-fold (0.24 log units) above what was measured; low and high end bracket the measured number.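

Placing a methoxy group on the aromatic ring of compound 2, ortho to a group of 9 heavy atoms and ortho to a methoxy group, gave a 2.1-fold lower number from compound 2 to compound 4 (0.32 log units; beyond the scatter) in this assay. Among the compounds shown here, this is only two examples, with the new group in a different place on each core, so they do not show that the step has one fixed size, that it would carry over to further cores, or why the number moves at all. Within those limits, the change looks alike on both cores, with the two steps too close to be told apart: the same change on two cores in this assay, a 1.3-fold lower number (0.13 log units; within the scatter) from compound 1 to compound 3 and a 2.1-fold lower number (0.32 log units; beyond the scatter) from compound 2 to compound 4, 1.5-fold (0.19 log units) apart, within the scatter of two such steps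

The compounds shown leave open whether an amine, a carboxylic acid or a longer chain such as ethoxy in the same place would move the number as methoxy does. They also leave open whether the step would hold on a core carrying chlorine in place of fluorine.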